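Benzothiophene for tolyl on a hydroxamic acid triazole

This account rests on a few compounds, and the source may have more. Where it says the series, first, only, none or still open, it means among the compounds named here.

Measured compounds:
Compound 1 `Cc1ccc(-c2nc(CNc3ccc(C(=O)NO)cc3)n(-c3ccccc3)n2)cc1` gives 224 nM in an assay on Sf9 cells for inhibition of protein deacetylase HDAC6 (Homo sapiens), read by fluorescence, with a stated time of 40 min; on this read-out higher numbers stand for weaker inhibition and lower numbers for stronger inhibition.
Compound 2 `O=C(NO)c1ccc(NCc2nc(-c3ccccc3)nn2-c2cccc(Cl)c2)cc1` gives 678 nM in this assay.

Compound 1 holds the lower of the two numbers on record in this assay, and the number of compound 2 stands at a distance that lies beyond the usual scatter of this measurement. Compound 3 `O=C(NO)c1ccc(NCc2nc(-c3cc4ccccc4s3)nn2-c2ccccc2)cc1` keeps the shared core of compound 1 and differs from it in one place: 1-benzothiophen-2-yl in place of 4-methylphenyl on an aromatic carbon. For the measured compounds named here, no measured pair on record shows this change, so its size in this assay is an open question. A larger aromatic group replacing a six-membered ring at this position could move the number either way, and a step beyond the scatter is not required by anything observed so far. Compound 3 is therefore expected to come in at 180 nM, within 50 nM to 650 nM, which means an expected step of a 1.2-fold lower number from compound 1 to compound 3 (0.09 log units; within the scatter).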

Compound 3, half-maximal inhibitory concentration: 324 nM
Compound 3: the middle estimate sits 1.8-fold (0.26 log units) below what was measured; the measured number falls inside the stated range.
By their numbers in this assay, from the lowest: compounds 1 and 3 (each within the scatter of the next); then compound 2.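

In this assay, for the compounds shown here, replacing 4-methylphenyl with 1-benzothiophen-2-yl gives a 1.4-fold higher number from compound 1 to compound 3 (0.16 log units; within the scatter) and is the first measured change at this position on the five-membered aromatic ring with 3 nitrogen. The position therefore accepts a group of 9 heavy atoms, with a five-membered aromatic ring fused to the six-membered one and a sulfur atom, in place of a group of 7 heavy atoms, with no step beyond the scatter. No measurement at hand gives a reason for this result.

The compounds shown leave open whether a plain thiophene or a smaller ring at this position would read the same way. They also leave open how this position responds to a group of a different kind, such as an amine, a carboxylic acid or a longer alkyl chain.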